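The source may report more compounds than this note shows. Statements on the series, on what has been measured and on what is new or still open speak of the compounds shown alone.

Two compounds share a core built around a seven-membered ring that carries a vinylcarbonyl group on its nitrogen. Compound 1 `C=CC(=O)N1C(=O)CC(c2ccc([N+](=O)[O-])cc2)Sc2ccccc21` bears a nitrophenyl group on the saturated ring carbon, and compound 2 `C=CC(=O)N1C(=O)CC(c2cccc(Cl)c2)Sc2ccccc21` bears a 3-chlorophenyl group at the same place. In a functional assay on HL-60 cells (Homo sapiens) for cytotoxicity, read by CCK-8 assay, with a stated time of 24 h (on this read-out higher numbers stand for weaker inhibition and lower numbers for stronger inhibition), compound 1 gives 107000 nM, and in this assay compound 2 gives 93100 nM. Compound 2 stands alongside compound 1: the two numbers lie within the usual scatter of each other, so neither can be called the stronger of the pair. Both are weak inhibitors on this read-out.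

Compound 3 `C=CC(=O)N1C(=O)CCSc2ccccc21` has not yet been measured. It differs from compound 2 in one place: hydrogen in place of 3-chlorophenyl on a saturated ring carbon. Among the measured compounds shown here, no measured pair shows what removing an aromatic ring from this position does, so the direction of the step must be guessed. The expected step from compound 2 to compound 3 is a 1.6-fold higher number from compound 2 to compound 3 (0.21 log units; within the scatter), a modest rise, since the whole aromatic ring is lost. Compound 3 is therefore estimated to give 150000 nM in this assay, with a range from 60000 nM to 400000 nM.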

Compound 3, half-maximal inhibitory concentration: 44800 nM
Beside the measured number, compound 3's estimate is 3.3-fold (0.52 log units) above it, and the stated range ends above it.
By their numbers in this assay, from the lowest: compound 3; then compounds 2 and 1 (each within the scatter of the next).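

Replacing 3-chlorophenyl with hydrogen on the saturated ring carbon next to the ring sulfur gives a 2.1-fold lower number from compound 2 to compound 3 (0.32 log units; beyond the scatter) in this assay. Among the compounds shown here, this is the first step at this position that lies beyond the scatter, and it shows that the aromatic ring is not needed for the activity seen on this read-out: the shared core with only hydrogen at this carbon does better than the 3-chlorophenyl compound. The gain is modest, however, and compound 3 at 44800 nM is still a weak inhibitor. No available information explains why losing the ring lowers the number.

The compounds shown leave open what a small group at this carbon, such as a methyl, an amine or a carboxylic acid, would do, and whether a longer chain would behave like hydrogen or like the aromatic ring. As far as these compounds go, all three compounds also carry the vinylcarbonyl group, so its contribution remains unknown, and a compound with an acetyl group in its place would be needed to address that.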